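The compounds below may be only part of what the source reports. "The series", "measured", "known", "first", "only" and "open" are said of these compounds alone.

In an ADME assay on L02 cells (Homo sapiens) for cytotoxicity, read by MTT assay (on this read-out lower numbers stand for stronger inhibition and higher numbers for weaker inhibition), compound 3 `C=CCOc1cc(/C=C/C(=O)c2ccc(OC)c3c2OC(C)(C)C=C3)ccc1OC` gives > 20000 nM as its reading, which is a limit and not a number. Compound 1 `COc1ccc(/C=C/C(=O)c2ccc(OC)c3c2OC(C)(C)C=C3)cc1OCC=C(C)C` gives > 10000 nM as its reading, also a limit. Compound 2 `C#CCOc1cc(/C=C/C(=O)c2ccc(OC)c3c2OC(C)(C)C=C3)ccc1OC` gives > 10000 nM as its reading, again a limit. Compound 4 `COc1ccc(/C=C/C(=O)c2ccc(OC)c3c2OC(C)(C)C=C3)cc1OCCCN(C)C` differs from compound 3 at one place: 2-(dimethylamino)ethyl in place of vinyl on a saturated chain carbon bound to an oxygen on an aromatic ring with 2-(dimethylamino)ethyl in place of vinyl. The nearest evidence comes from changes at the same place: a step that the two limits leave unreadable from compound 1 to compound 2 and a step that the two limits leave unreadable from compound 1 to compound 3 and a step that the two limits leave unreadable from compound 2 to compound 3 in this series. None of these steps has a readable size, so they set neither a size nor a direction for the new change. The expected at least 1.3-fold lower number from compound 3 to compound 4 (0.12 log units; that floor lies within the scatter) is therefore only a loose estimate. In this assay compound 4 is estimated at 15000 nM within a range of 5000 nM to 40000 nM as a working expectation.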

Compound 4, half-maximal inhibitory concentration: 8600 nM
For compound 4 the middle estimate is 1.7-fold (0.24 log units) above the measured one, within the range that was stated.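

In this assay, compound 4 gives this position its first reading that is a number rather than a limit, and the steps among the three earlier compounds cannot be read. Replacing allyloxy with 3-(dimethylamino)propoxy gives an at least 2.3-fold lower number from compound 3 to compound 4 (0.36 log units; beyond the scatter). The other two steps, an at least 1.1-fold lower number from compound 2 to compound 4 (0.06 log units; that floor lies within the scatter) and an at least 1.1-fold lower number from compound 1 to compound 4 (0.06 log units; that floor lies within the scatter), have floors that do not by themselves establish a real change. On these data alone, what remains open is whether the nitrogen matters or the chain alone does. A plain butyl chain or a carboxylic acid on the same oxygen would help separate the two.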